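Swapping a thiadiazole for a tetrazole on the sulfur

This account rests on a few compounds, and the source may have more. Where it says the series, first, only, none or still open, it means among the compounds named here.

Three compounds have been measured in a functional assay on C6 cells (Rattus norvegicus) for cytotoxicity, read by MTT assay, with a stated time of 24 h, tested at 12 ug/mL; on this read-out lower numbers stand for a stronger effect and higher numbers for a weaker effect at the one concentration tested:

Compound 1, `Cc1nnc(SCC(=O)N/N=c2/scc(-c3ccccc3)n2-c2ccccc2)s1`: 72.5%
Compound 2, `Cc1nnc(SCC(=O)N/N=c2/scc(-c3ccc(F)cc3)n2-c2ccccc2)s1`: 73.7%
Compound 3, `Cc1ccc(-c2cs/c(=N/NC(=O)CSc3nnc(C)s3)n2-c2ccccc2)cc1`: 58.3%

Compound 1 stands second highest of these three numbers. Its nearest neighbour is compound 2, with a number 1.2 percentage points higher from compound 1 to compound 2 (within the scatter), a step that lies within the scatter. The furthest is compound 3, with a number 14.2 percentage points lower from compound 1 to compound 3 (beyond the scatter), and the related step of a number 15.4 percentage points lower from compound 2 to compound 3 (beyond the scatter) points the same way. Both of those steps change a group on an aromatic carbon of a phenyl ring.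

The next compound is compound 4, `Cn1nnnc1SCC(=O)N/N=c1/scc(-c2ccccc2)n1-c1ccccc1`. Compared with compound 1 it carries 1-methyl-1H-tetrazol-5-yl in place of 5-methyl-1,3,4-thiadiazol-2-yl on a sulfur. Among the measured compounds shown here, none of the measured steps touch this part of the molecule; they all concern the phenyl ring, so they give no direct guide to how this exchange behaves in this assay. For the measured compounds named here, with no step to lean on, the expectation for compound 4 is a number close to that of compound 1, a step of a number 0.5 percentage points lower from compound 1 to compound 4 (within the scatter) that is not expected to go beyond the scatter. The estimate for compound 4 is 72%, expected to fall between 58% and 86%.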

Compound 4, a percentage reported as activity, at one concentration (the size of the read-out at that concentration, not a potency): 80.7%
Estimate against measurement, compound 4: 8.7 percentage points below; low and high end bracket the measured number.
By their numbers in this assay, from the lowest: compound 3; then compounds 1, 2 and 4 (each within the scatter of the next).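

Among the compounds shown here, the step of a number 8.2 percentage points higher from compound 1 to compound 4 (within the scatter) in this assay is the first reading at this position, and it does not separate 1-methyl-1H-tetrazol-5-yl from 5-methyl-1,3,4-thiadiazol-2-yl on a sulfur. The earlier steps shown here all changed a phenyl ring, whereas this one shows that the five-membered aromatic ring on the sulfur can go from 3 hetero atoms to 4 without a step beyond the scatter. Nothing measured here bears on why the two compounds read this way.

This exchange is shown only against compound 1, so whether it would read the same with the methyl group of compound 3 on the phenyl ring stays open. Also open, on these data alone, is how this assay would respond to a group without a ring on the sulfur, such as an ethyl chain or a carboxylic acid.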